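A few compounds are considered here, and "the series" means these few. Any claim that something is new, unique, unknown or untested is made for them only; others in the source may bear on it.

Compound 1 `Cc1ccc(OCC(=O)N(Cc2cccs2)c2cccnc2)cc1` gives 198 nM in an assay on HEK293 cells for agonist activity at transient receptor potential cation channel subfamily M member 8 (Homo sapiens), read by fluorescence and calcium flux, with a stated time of 15 min; a higher number here means that more compound is needed for the effect, a lower number that less compound is needed.
Compound 2 `Cc1ccc(OCC(=O)N(Cc2cccs2)c2ccn(C)n2)cc1` gives 855 nM in this assay.
Compound 3 `CCN(Cc1cncs1)C(=O)COc1ccc(C)cc1` gives 1100 nM in this assay.

Compound 2 stands second highest of the three numbers. Its nearest neighbour is compound 3, whose value lies within the scatter of that of compound 2, so the two cannot be told apart. Among the compounds with values here, compound 1 lies furthest away: the change a 4.3-fold higher number from compound 1 to compound 2 (0.64 log units; beyond the scatter) is the only measured step that alters the group on the amide-type nitrogen, and it is modest but beyond the scatter.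

Compound 4 `Cc1ccc(OCC(=O)N(Cc2cccs2)C2CCCCC2)cc1` differs from compound 2 by cyclohexyl in place of 1-methyl-1H-pyrazol-3-yl on an amide-type nitrogen. Within the data shown here, the one measured step at this position exchanged one aromatic ring for another and moved the number modestly; the move to cyclohexyl has no direct precedent among the measured compounds, so its direction is uncertain. Compound 4 is therefore expected to land close to compound 2 in this assay, with a step of a 1.4-fold lower number from compound 2 to compound 4 (0.15 log units; within the scatter) that may well stay within the scatter. The estimate for compound 4 is 600 nM, within a range from 150 nM to 3000 nM.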

Compound 4, half-maximal effective concentration: 40000 nM
For compound 4 the middle estimate is 67-fold (1.82 log units) below the measured one; measured number outside the range, above it.
By their numbers in this assay, from the lowest: compound 1; then compounds 2 and 3 (each within the scatter of the next); then compound 4.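

In this assay, within the data shown here, the group on the amide-type nitrogen matters far more than the one earlier step could show: exchanging one aromatic ring for another gave only a 4.3-fold higher number from compound 1 to compound 2 (0.64 log units; beyond the scatter), whereas cyclohexyl gives a 47-fold higher number from compound 2 to compound 4 (1.67 log units; beyond the scatter) and a 200-fold higher number from compound 1 to compound 4 (2.31 log units; beyond the scatter). Cyclohexyl has the same count of heavy atoms as 1-methyl-1H-pyrazol-3-yl, so that count does not separate compound 2 from compound 4; what differs is a non-aromatic ring of carbon only in place of an aromatic ring with hetero atoms. Nothing measured here accounts for this difference.

The compounds shown leave open whether the aromaticity of the ring or its nitrogen atoms count at this position. A phenyl group would speak to the first question, and a piperidin-4-yl group to the second.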